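The compounds below may be only part of what the source reports. "The series", "measured", "known", "first", "only" and "open" are said of these compounds alone.

Working notes on the series. In a functional assay on HL-60 cells (Homo sapiens) for cytotoxicity, read by sulforhodamine B assay (a higher number here means a weaker inhibitor, a lower number a stronger inhibitor), compound 1 (`COc1ccc(Cn2c3c(c4ccc(C)cc4c2=O)CCOc2ccccc2-3)cc1`) gives 4400 nM, compound 2 (`COCOc1ccccc1-c1cc2ccccc2c(=O)[nH]1`) gives 620 nM, and compound 3 (`COCOc1ccccc1-c1cc2cc(C)ccc2c(=O)[nH]1`) gives 160 nM, the lowest of the three numbers.

The next compound is compound 4 (`COCOc1ccccc1-c1cc2cc(C)ccc2c(=O)n1C`), which differs from compound 3 by one change: methyl in place of hydrogen on an aromatic nitrogen. In words, this is methyl in place of hydrogen on an aromatic nitrogen.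

Within the data shown here, only one measured step changes a single place: a 3.9-fold lower number from compound 2 to compound 3 (0.59 log units; beyond the scatter). That step also brings in a methyl, but on an aromatic carbon, so it bears on the new change only loosely. Among the measured compounds shown here, no measured step covers methyl on this nitrogen.

For the measured compounds named here, the sole hint comes from compound 1, which has no amide hydrogen and gives 4400 nM. It differs from compound 3 in more than one place, so this is weak support. Compounds 2 and 3 both keep that hydrogen, and both have lower numbers.

A modest move toward a higher number in this assay is therefore expected, though with wide uncertainty. The expected size is a 4.4-fold higher number from compound 3 to compound 4 (0.64 log units; beyond the scatter). For compound 4 the estimated value is 700 nM, with an expected range of 200 nM to 3000 nM.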

Compound 4, half-maximal inhibitory concentration: 14300 nM
Estimate against measurement, compound 4: 20-fold (1.31 log units) below; measured number above the stated range.
By their numbers in this assay, from the lowest: compound 3; then compound 2; then compound 1; then compound 4.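

In this assay, among these compounds, methyl in place of hydrogen on the aromatic nitrogen gives an 89-fold higher number from compound 3 to compound 4 (1.95 log units; beyond the scatter), a large step and the only measured change at this position. The same group on an aromatic carbon moves the number the other way, with a 3.9-fold lower number from compound 2 to compound 3 (0.59 log units; beyond the scatter), so across these two steps the direction follows the place of the methyl and not the methyl alone. The data shown give no measured basis for explaining the size of the step at the nitrogen.

As far as these compounds go, it remains open whether any group on this nitrogen gives a similar rise or whether the result is particular to methyl; an ethyl group, a longer chain or a chain ending in an amine would separate these cases. From the compounds shown here alone, it also remains open whether the step at the nitrogen has the same size without the methyl on the aromatic carbon, which would take a direct comparison with compound 2 carrying methyl on this nitrogen.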